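Ester in place of ether on the shared lactone-bearing core

A few compounds are considered here, and "the series" means these few. Any claim that something is new, unique, unknown or untested is made for them only; others in the source may bear on it.

Compound 2 `C=CCO[C@H]1C[C@@H](C)C=C2C=C[C@H](C)[C@H](CCC3C[C@@H](O)CC(=O)O3)[C@H]21` carries an allyl ether on its core. Among the compounds with values here, in an assay for inhibition of 3-hydroxy-3-methylglutaryl-coenzyme A reductase (Rattus norvegicus) (a higher number here means a weaker inhibitor, a lower number a stronger inhibitor), compound 2 gives 370 nM, the higher of the two numbers known so far. Within the data shown here, its only measured neighbour is compound 1 `C[C@H]1C=C2C=C[C@H](C)[C@H](CCC3C[C@@H](O)CC(=O)O3)[C@H]2[C@@H](OCc2ccc(F)cc2)C1`, which in this assay gives 4.7 nM; the step of a 79-fold higher number from compound 1 to compound 2 (1.90 log units; beyond the scatter) shows how much weaker compound 2 is.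

Compound 3 `C=CCC(=O)O[C@H]1C[C@@H](C)C=C2C=C[C@H](C)[C@H](CCC3C[C@@H](O)CC(=O)O3)[C@H]21` differs from compound 2 by allylcarbonyl in place of allyl on an oxygen on a saturated carbon, so that the allyl ether becomes an allylcarbonyl ester. Among the measured compounds shown here, no measured step bears on an ether-to-ester exchange at this oxygen; the one step known, a 79-fold higher number from compound 1 to compound 2 (1.90 log units; beyond the scatter), concerns a different exchange of the group on the chain carbon and says nothing about adding a carbonyl. The expectation for compound 3 therefore rests on little, and only a modest step in this assay is expected, most likely toward a lower number. The estimate for compound 3 is 150 nM, with a range from 30 nM to 1000 nM, which corresponds to an expected step of a 2.5-fold lower number from compound 2 to compound 3 (0.39 log units; beyond the scatter).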

Compound 3, half-maximal inhibitory concentration: 2.9 nM
Compound 3: the middle estimate sits 52-fold (1.71 log units) above what was measured, outside the stated range (below it).
By their numbers in this assay, from the lowest: compounds 3 and 1 (each within the scatter of the next); then compound 2.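

In this assay the exchange of allyl for allylcarbonyl on this oxygen gives a 130-fold lower number from compound 2 to compound 3 (2.11 log units; beyond the scatter) and so shows that the group on the oxygen can move the number over a wide span even when it carries no ring. The earlier step of a 79-fold higher number from compound 1 to compound 2 (1.90 log units; beyond the scatter) could have been read as a need for the 4-fluorophenyl group, but a 1.6-fold lower number from compound 1 to compound 3 (0.21 log units; within the scatter) stays within the scatter, so allylcarbonyl, which has no ring, and 4-fluorobenzyl are not told apart in this assay, and of the three compounds only compound 2 with its allyl ether stands apart. Nothing in the data given accounts for the size of this change, or for why two such different groups land so close together.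

The compounds shown leave open whether the carbonyl alone carries the change or whether the length of the allylcarbonyl chain also matters, and an acetyl ester or a saturated butanoyl ester on this oxygen would separate the two. On these data alone, it is also open whether a carbamate or a 4-fluorobenzoyl ester at this position would fall with compound 3 or with compound 2.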